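A few compounds are considered here, and "the series" means these few. Any claim that something is new, unique, unknown or untested is made for them only; others in the source may bear on it.

Measured compounds:
compound 1 `Cc1cc(O)cc(-c2nn(CC#N)cc2-c2ccnc(-c3ccc(Oc4ccccc4)cc3)c2)c1` — a functional assay on RPMI8266 cells (Homo sapiens) for cytotoxicity, read by sulforhodamine B assay, with a stated time of 48 h, tested at 1 uM; a lower number here means a stronger effect, a higher number a weaker effect of the compound at the concentration tested: -20%
compound 2 `COc1cc(C)cc(-c2nn(CC#N)cc2-c2ccnc(-c3ccc(N(C)C)cc3)c2)c1` — in this assay compound 2 gives 1%

Among the measured compounds shown here, of the two numbers so far, compound 2 stands highest, that is weakest; its nearest neighbour is compound 1, whose value lies beyond the usual scatter below it. The two differ in more than one place, so their gap is not broken down into single steps here.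

The next compound is compound 3 `Cc1cc(O)cc(-c2nn(CC#N)cc2-c2ccnc(-c3ccc(N(C)C)cc3)c2)c1`. It differs from compound 2 by hydrogen in place of methyl on an oxygen on an aromatic ring, a change of methoxy to hydroxy on the 3-methoxy-5-methylphenyl group. Compound 1 carries this same hydroxy group and gives -20%, but it also carries a different group on its other aryl ring, so the hydroxy change alone cannot be read from it. A modest downward step a number 9 percentage points lower from compound 2 to compound 3 (within the scatter) is expected, close to the edge of the scatter. Compound 3 is estimated at -8%, within -35% to 15%.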

Compound 3, a percentage reported as activity, at one concentration (the size of the read-out at that concentration, not a potency): 15%
Estimate against measurement, compound 3: 23 percentage points below; measured number inside the range.
By their numbers in this assay, from the lowest: compound 1; then compound 2; then compound 3.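

In this assay, with the dimethylamino group held fixed, the change from methoxy to hydroxy on the 3-methoxy-5-methylphenyl group gives a number 14 percentage points higher from compound 2 to compound 3 (beyond the scatter), so on this background the hydroxy compound reads weaker than its methoxy partner, which the first two compounds could not show. With the hydroxy group held fixed, dimethylamino in place of phenoxy on the aromatic carbon gives a number 35 percentage points higher from compound 1 to compound 3 (beyond the scatter), a large step that separates the contribution of that group from the modest methoxy-to-hydroxy step. Nothing given here accounts for either step.

As far as these compounds go, whether the methoxy-to-hydroxy step keeps its direction with phenoxy in place of dimethylamino remains open. So does the effect of an amine or a carboxylic acid in place of the hydroxy group, or of a longer chain such as ethoxy on that oxygen.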